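A Methoxy Group in Place of Fluoro on a Shared Core

The compounds below may be only part of what the source reports. "The series", "measured", "known", "first", "only" and "open" are said of these compounds alone.

Compound 1 `Nc1cc(N)c2nc(-c3ccccc3)c(Sc3ccc(F)cc3)nc2c1` and compound 2 `COc1ccc(CNc2nc3cc(N)cc(N)c3nc2-c2ccccc2)cc1OC` share the same core and have both been tested in a functional assay on NCI/ADR-RES cells (Homo sapiens) for inhibition, read by sulforhodamine B assay, with a stated time of 48 h; a lower number here means a stronger inhibitor of growth, a higher number a weaker inhibitor of growth. In this assay compound 1 gives 34700 nM, and in this assay compound 2 gives 66100 nM. Compound 1 has the lower of the two numbers, but its gap to compound 2 falls within the usual scatter of repeated measurements, so on these data the two compounds cannot be told apart.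

Compound 3 `COc1ccc(Sc2nc3cc(N)cc(N)c3nc2-c2ccccc2)cc1` has not yet been measured. It differs from compound 1 in one place: methoxy in place of fluoro on an aromatic carbon. For the measured compounds named here, no pair of measured compounds shows what this kind of change does on the shared core, so there is nothing to build on beyond the two numbers already in hand and the modest size of the change itself.

The expected step is small, a 1.2-fold higher number from compound 1 to compound 3 (0.06 log units; within the scatter), with no direction beyond the scatter. The value of compound 3 in this assay is estimated at 40000 nM, with a likely range from 15000 nM to 100000 nM.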

Compound 3, concentration for total growth inhibition: < 100000 nM
Compound 3 was reported as a limit; the forecaster's own chance of this, stated with the estimate: 10%; the middle value is on the limit's open side.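

In this assay, for the compounds shown here, compound 3 gives < 100000 nM which is a limit and not a number, so no step from compound 1 to compound 3 can be read. The compounds shown leave open what methoxy in place of fluoro does to growth inhibition on the shared core, in either size or direction.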